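Moving the Chlorines: From Compound 3 to Compound 4

The source may report more compounds than this note shows. Statements on the series, on what has been measured and on what is new or still open speak of the compounds shown alone.

Compound 1 (`Cc1ccc(N(C(=O)c2ccccc2C)C(=S)OCCN2C(=O)c3ccccc3C2=O)cc1`) reads > 100000 nM in an ADME assay on MT4 cells (Homo sapiens) for cytotoxicity, read by MTT assay (a higher number here means that more compound is tolerated, a lower number that less compound is tolerated), which is a limit of the assay and not a number. Compound 2 (`Cc1ccc(N(C(=O)c2c(F)cccc2F)C(=S)OCCN2C(=O)c3ccccc3C2=O)cc1`) gives 65000 nM in this assay. Compound 3 (`Cc1ccc(N(C(=O)c2cccc(Cl)c2Cl)C(=S)OCCN2C(=O)c3ccccc3C2=O)cc1`) gives 35000 nM, and it stands level with compound 2 within the scatter, the step being a 1.9-fold lower number from compound 2 to compound 3 (0.27 log units; within the scatter). Measured against the limit of compound 1, the other two steps are an at least 1.5-fold lower number from compound 1 to compound 2 (0.18 log units; that floor lies within the scatter) and an at least 2.8-fold lower number from compound 1 to compound 3 (0.45 log units; beyond the scatter).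

Compound 4 (`Cc1ccc(N(C(=O)c2ccc(Cl)c(Cl)c2)C(=S)OCCN2C(=O)c3ccccc3C2=O)cc1`) carries 3,4-dichlorophenyl in place of 2,3-dichlorophenyl on a carbonyl carbon. Among the compounds with values here, no measured step makes this exact exchange. The nearest guide is the swap between two halogenated groups at that carbonyl carbon, a 1.9-fold lower number from compound 2 to compound 3 (0.27 log units; within the scatter), which stays within the scatter. No step beyond the scatter is therefore expected in this assay, and any shift could go either way. The estimated step is a 1.3-fold higher number from compound 3 to compound 4 (0.11 log units; within the scatter). Compound 4 is expected at 45000 nM, with an estimated range of 18000 nM to 100000 nM.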

Compound 4, half-maximal cytotoxic concentration: 17000 nM
Beside the measured number, compound 4's estimate is 2.6-fold (0.42 log units) above it; the whole stated range lies above it.
By their numbers in this assay, from the lowest: compound 4; then compounds 3 and 2 (each within the scatter of the next). At a limit, above all of these: compound 1.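

Moving the two chlorines, with the same atoms joined differently, changes the reading in this assay: a 2.1-fold lower number from compound 3 to compound 4 (0.31 log units; beyond the scatter), whereas the earlier exchange between halogenated groups at this carbonyl carbon stayed within the scatter. This position therefore responds to the arrangement of the chlorines and not only to their presence, and 3,4-dichlorophenyl gives the lowest number of the four, with a 3.8-fold lower number from compound 2 to compound 4 (0.58 log units; beyond the scatter) and an at least 5.8-fold lower number from compound 1 to compound 4 (0.76 log units; beyond the scatter). Compound 1 stands at a limit of the assay and not at a number: the limit of > 100000 nM in this assay, at which 1 of the 4 values shown sits.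

The compounds shown leave open whether a single chlorine on this phenyl would read closer to compound 3 or to compound 4. They also leave open how a methoxy or trifluoromethyl group in place of the chlorines would read.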